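The source may hold more compounds than are shown below. What is called first, only, known or untested is meant among the compounds shown, and "the series" means these compounds.

Compound 1 `CC#CCN(C)Cc1cc2cc(O)ccc2n1C` is the strongest of the three compounds measured in an assay on isolated protein for inhibition of Amine oxidase [flavin-containing] A (Rattus norvegicus) (a higher number here means a weaker inhibitor, a lower number a stronger inhibitor), where compound 1 gives 5.75 nM. Compound 2 `C#CCN(C)Cc1cn(Cc2ccccc2)c2ccccc12` gives 158000 nM in this assay, and compound 3 `CCNCc1cn(Cc2ccccc2)c2ccccc12` gives 263000 nM. The change from compound 1 to compound 4 `C#CCNCc1cc2cc(O)ccc2n1C` is propargylamino in place of (but-2-yn-1-yl)(methyl)amino on a saturated chain carbon bound to an aromatic carbon. Among the compounds with values here, only one measured step touches the same place, the amine on the saturated chain carbon: a 1.7-fold higher number from compound 2 to compound 3 (0.22 log units; within the scatter), which hardly moved the number. That step, though on a different core, suggests that swapping substituents on this nitrogen changes little, so compound 4 is expected to lose only a modest amount, a 3.5-fold higher number from compound 1 to compound 4 (0.54 log units; beyond the scatter). Compound 4 is therefore estimated at 20 nM, with a likely range from 3 nM to 150 nM.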

Compound 4, inhibition constant: 3980 nM
Estimate against measurement, compound 4: 200-fold (2.30 log units) below, outside the stated range (above it).
By their numbers in this assay, from the lowest: compound 1; then compound 4; then compounds 2 and 3 (each within the scatter of the next).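

In this assay, the amine on the saturated chain carbon proves highly sensitive on the core of compound 1, with a 690-fold higher number from compound 1 to compound 4 (2.84 log units; beyond the scatter). The flat result of a 1.7-fold higher number from compound 2 to compound 3 (0.22 log units; within the scatter), seen on another core, therefore does not carry over to this one. No measurement shown here explains the loss.

The compounds shown leave open whether the loss follows the methyl on the nitrogen or the but-2-yn-1-yl chain, since both differ in this step. A (but-2-yn-1-yl)amino group on the same core would separate the two.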